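Swapping the side group of compound 1

A few compounds are considered here, and "the series" means these few. Any claim that something is new, unique, unknown or untested is made for them only; others in the source may bear on it.

Measured values in a functional assay on HCT-116 cells (Homo sapiens) for cytotoxicity, read by MTT assay, with a stated time of 72 h (a lower number here means a stronger inhibitor, a higher number a weaker inhibitor), are:
compound 1 `CC1(C)OCC(Cn2cc(Cn3c4c(c5ccccc53)C(=O)c3c[n+]([O-])c5ccccc5c3C4=O)nn2)O1` gives 70 nM
compound 2 `CN1CCN(CCCCn2c3c(c4ccccc42)C(=O)c2c[n+]([O-])c4ccccc4c2C3=O)CC1` gives 10 nM
compound 3 `O=C1c2c[n+]([O-])c3ccccc3c2C(=O)c2c1c1ccccc1n2CCCCN1CCNCC1` gives 700 nM

Compound 1 has the second highest number of the three, with a higher number than compound 2 (10 nM) and a lower one than compound 3 (700 nM). The next compound keeps the core of compound 1 and changes one group. In compound 4 `O=C1c2c[n+]([O-])c3ccccc3c2C(=O)c2c1c1ccccc1n2Cc1cn([C@H]2C[C@H](O)[C@@H](CO)O2)nn1`, 4-hydroxy-5-(hydroxymethyl)oxolan-2-yl stands in place of (2,2-dimethyl-1,3-dioxolan-4-yl)methyl on an aromatic nitrogen of a five-membered aromatic ring with 3 nitrogen (4-hydroxy-5-(hydroxymethyl)oxolan-2-yl in place of (2,2-dimethyl-1,3-dioxolan-4-yl)methyl on an aromatic nitrogen).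

Among the measured compounds shown here, no measured step touches this group. The nearest guide is a 70-fold higher number from compound 2 to compound 3 (1.85 log units; beyond the scatter), where hydrogen replaces methyl on an amine nitrogen in a ring. That step is large and beyond the scatter, yet it sits on a different side chain, so it bears on this change only loosely. It does show that one small edit can move the number far among these compounds. Its direction hints weakly at a rise, since methyl left there and the leaving group here carries 2,2-dimethyl.

The expected change is a 2.9-fold higher number from compound 1 to compound 4 (0.46 log units; beyond the scatter) (this assay), a moderate rise with wide uncertainty. Compound 4 is expected at 200 nM (estimated range 40 nM to 1000 nM) in this measurement.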

Compound 4, half-maximal inhibitory concentration: 120 nM
The estimate for compound 4 lay 1.7-fold (0.22 log units) above the measured number; the measured number falls inside the stated range.
By their numbers in this assay, from the lowest: compound 2; then compounds 1 and 4 (each within the scatter of the next); then compound 3.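

In this assay, placing 4-hydroxy-5-(hydroxymethyl)oxolan-2-yl on the aromatic nitrogen instead of (2,2-dimethyl-1,3-dioxolan-4-yl)methyl gives a 1.7-fold higher number from compound 1 to compound 4 (0.23 log units; within the scatter), so this measurement does not tell the two groups apart. This position therefore tolerates a real change of group, from one with 0 hydrogen-bond donors and no defined stereocentres to one with 2 donors and 3 defined stereocentres, without a shift beyond the scatter. That contrasts with the side chain of the earlier pair, where one small edit gave a 70-fold higher number from compound 2 to compound 3 (1.85 log units; beyond the scatter), though the two steps sit on different side chains and involve different groups. No measurement is available to explain why this swap leaves the number within the scatter.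

Among the compounds shown here, only two groups at this position can be compared here, so they say nothing about how a carboxylic acid, a primary amine or a longer carbon chain would behave in the same place. It also remains open whether the 3 defined stereocentres of the entering group matter, since no compound shown carries the same group with a different arrangement at those centres.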